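Hydroxy in place of methoxy on the dimethylaminophenyl series

The source may hold more compounds than are shown below. What is called first, only, known or untested is meant among the compounds shown, and "the series" means these compounds.

Measured so far:
compound 1 `Cc1cc(O)cc(-c2nn(CC#N)cc2-c2ccnc(-c3ccc(Oc4ccccc4)cc3)c2)c1`: 6540 nM
compound 2 `COc1cc(C)cc(-c2nn(CC#N)cc2-c2ccnc(-c3ccc(N(C)C)cc3)c2)c1`: 98700 nM

In a functional assay on UO-31 cells (Homo sapiens) for inhibition, read by sulforhodamine B assay, with a stated time of 48 h (on this read-out lower numbers stand for stronger inhibition of growth and higher numbers for weaker inhibition of growth), compound 2 gives the higher of the two numbers in hand, with 98700 nM; compound 1 gives 6540 nM, and the gap between the two lies beyond the usual scatter. The two compounds differ at two places at once, so neither place can be credited on its own.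

Compound 3 `Cc1cc(O)cc(-c2nn(CC#N)cc2-c2ccnc(-c3ccc(N(C)C)cc3)c2)c1` is not yet measured. It differs from compound 2 by hydrogen in place of methyl on an oxygen on an aromatic ring, that is, methoxy to hydroxy, 3-methoxy-5-methylphenyl to 3-hydroxy-5-methylphenyl. Among the measured compounds shown here, no pair of measured compounds shows this single change, so the direction rests on compound 1, which carries the hydroxy and gives 6540 nM. A moderate step downward is expected, without certainty that it exceeds the scatter. For compound 3 the expected value in this assay is 40000 nM, with a range from 10000 nM to 150000 nM. The expected step is a 2.5-fold lower number from compound 2 to compound 3 (0.39 log units; beyond the scatter).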

Compound 3, concentration for total growth inhibition: 32500 nM
Compound 3: the middle estimate sits 1.2-fold (0.09 log units) above what was measured; measured number inside the range.
By their numbers in this assay, from the lowest: compound 1; then compound 3; then compound 2.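

In this assay methoxy to hydroxy, 3-methoxy-5-methylphenyl to 3-hydroxy-5-methylphenyl, now reads on its own as a 3.0-fold lower number from compound 2 to compound 3 (0.48 log units; beyond the scatter) and so accounts for part of the gap that the first two compounds left undivided. The second place also reads on its own: dimethylamino in place of phenoxy on an aromatic carbon gives a 5.0-fold higher number from compound 1 to compound 3 (0.70 log units; beyond the scatter) with the hydroxy held fixed. Among these three compounds, hydroxy and phenoxy each go with the lower number in their pair, and both steps are modest.

From the compounds shown here alone, whether an ethoxy group on that oxygen, or an amine or a carboxylic acid in place of the hydroxy, would extend this step remains open. Nothing in hand explains either step.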